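This account rests on a few compounds, and the source may have more. Where it says the series, first, only, none or still open, it means among the compounds named here.

Measured so far in a functional assay on HepG2 cells (Homo sapiens) for antiproliferative activity, read by MTT assay, with a stated time of 24 h; on this read-out higher numbers stand for weaker inhibition and lower numbers for stronger inhibition:

- Compound 1 `Clc1ccccc1CSc1nnc(-c2ccc3c(c2)OCCO3)n1-c1ccccc1`: 970 nM
- Compound 2 `Clc1cccc(CSc2nnc(-c3ccc4c(c3)OCCO4)n2-c2ccccc2)c1`: 2390 nM
- Compound 3 `Cc1ccc(CSc2nnc(-c3ccc4c(c3)OCCO4)n2-c2ccccc2)cc1`: 56800 nM

Compound 3 has the highest number of the three, which makes it the weakest inhibitor of this small set. Compound 4 `Fc1cccc(F)c1CSc1nnc(-c2ccc3c(c2)OCCO3)n1-c1ccccc1` keeps the shared core and changes one group, on a saturated chain carbon bound to a sulfur: 2,6-difluorophenyl in place of 4-methylphenyl (2,6-difluorophenyl in place of 4-methylphenyl on a saturated chain carbon bound to a sulfur).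

Two large steps bear on this change, and both end at compound 3: a 59-fold higher number from compound 1 to compound 3 (1.77 log units; beyond the scatter) and a 24-fold higher number from compound 2 to compound 3 (1.38 log units; beyond the scatter). The two compounds with a chlorophenyl group differ far less: a 2.5-fold higher number from compound 1 to compound 2 (0.39 log units; beyond the scatter). In these three compounds, the numbers are much lower without the 4-methylphenyl group. Going by the values given here, no compound with fluorine has been measured, however, so the size of the step remains uncertain. A large drop in this assay is expected, as a 19-fold lower number from compound 3 to compound 4 (1.28 log units; beyond the scatter). For compound 4 the estimate is 3000 nM, with an expected range of 700 nM to 20000 nM.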

Compound 4, half-maximal inhibitory concentration: 2070 nM
Compound 4: the middle estimate sits 1.4-fold (0.16 log units) above what was measured; the range from low to high includes it.
By their numbers in this assay, from the lowest: compound 1; then compounds 4 and 2 (each within the scatter of the next); then compound 3.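

In this assay, 2,6-difluorophenyl gives a 27-fold lower number from compound 3 to compound 4 (1.44 log units; beyond the scatter) on this saturated chain carbon bound to a sulfur, so a low number at this place does not require a chlorophenyl group, and among these four compounds only the one with 4-methylphenyl stands far off. Compared with the chlorophenyl groups, the change gives a 1.2-fold lower number from compound 2 to compound 4 (0.06 log units; within the scatter) with 3-chlorophenyl as the starting point and a 2.1-fold higher number from compound 1 to compound 4 (0.33 log units; beyond the scatter) with 2-chlorophenyl as the starting point, which leaves 2-chlorophenyl with the lowest number of the four. No supporting data are available to explain these differences.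

Still open, on these data alone, is whether plain phenyl, 4-chlorophenyl or an aminophenyl group would stay close to the chlorophenyl compounds or move towards compound 3. A longer chain between the sulfur and the ring also remains untested in the compounds shown here.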